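Swapping the aryl cap: compound 3 to compound 4

The source may report more compounds than this note shows. Statements on the series, on what has been measured and on what is new or still open speak of the compounds shown alone.

Of the compounds shown here, three sharing one core have been measured in an assay on isolated protein with Bile acid receptor (Homo sapiens) as the target; on this read-out higher numbers stand for an effect only at larger amounts of compound and lower numbers for an effect already at smaller amounts. Compound 1 `COC(=O)/C=C/c1cccc(N(Cc2ccc(/C=C/c3c(Cl)cccc3Cl)cc2)C(=O)C(C)C)c1` gives 195 nM. Compound 2 `COC(=O)/C=C/c1cccc(N(Cc2ccc(-c3ccc(C)cc3)cc2)C(=O)C(C)C)c1` gives 118 nM. Compound 3 `COC(=O)/C=C/c1cccc(N(Cc2ccc(-c3cc(Cl)ccc3OC)cc2)C(=O)C(C)C)c1` gives 226 nM, the largest of the three numbers, but the gaps to its neighbours are small: a 1.2-fold higher number from compound 1 to compound 3 (0.06 log units; within the scatter) and a 1.9-fold higher number from compound 2 to compound 3 (0.28 log units; within the scatter). For the measured compounds named here, the first pair of compounds is likewise close, a 1.7-fold lower number from compound 1 to compound 2 (0.22 log units; within the scatter). In short, none of the three changes so far has moved this assay beyond its usual scatter.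

Compound 4 `COC(=O)/C=C/c1cccc(N(Cc2ccc(-c3ccc(F)c(Cl)c3)cc2)C(=O)C(C)C)c1` has not yet been measured. It differs from compound 3 in one place: 3-chloro-4-fluorophenyl in place of 5-chloro-2-methoxyphenyl on an aromatic carbon. Going by the values given here, the steps that bear on this change are those exchanging the same outer group, from compound 1 to compound 2 and from compound 2 to compound 3, both within the scatter. Since three different groups at this position gave numbers that cannot be told apart, a fourth is expected to do the same. The estimated step from compound 3 to compound 4 is therefore a 1.4-fold lower number from compound 3 to compound 4 (0.15 log units; within the scatter), a change not expected to exceed the scatter. Compound 4 is expected to give about 160 nM in this assay, with a range from 70 nM to 350 nM.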

Compound 4, half-maximal effective concentration: 129 nM
Compound 4: middle estimate off by 1.2-fold (0.09 log units), on the high side, within the range that was stated.
By their numbers in this assay, from the lowest: compounds 2, 4, 1 and 3 (each within the scatter of the next).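

In this assay, the new group stays within the scatter of all three earlier groups: a 1.8-fold lower number from compound 3 to compound 4 (0.24 log units; within the scatter), a 1.1-fold higher number from compound 2 to compound 4 (0.04 log units; within the scatter) and a 1.5-fold lower number from compound 1 to compound 4 (0.18 log units; within the scatter). For the compounds shown here, this adds something the earlier compounds did not show, since 3-chloro-4-fluorophenyl carries fluorine and has no oxygen or hydrogen-bond acceptor, unlike 5-chloro-2-methoxyphenyl, and yet the numbers of compounds 1, 2, 3 and 4 still cannot be told apart, so at this position neither that exchange of atoms nor the loss of the acceptor produces a step beyond the scatter. No measurement at hand accounts for this flat result.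

On these data alone, all four outer groups contain a six-membered aromatic ring of carbon only, so it stays open whether a pyridine ring, an amine or a plain alkyl chain at this position would produce a step beyond the scatter. The four compounds also share the rest of the core, so they say nothing about other changes, such as a carboxylic acid in place of the methyl ester.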